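This account rests on a few compounds, and the source may have more. Where it says the series, first, only, none or still open, it means among the compounds named here.

In a functional assay on HCT-116 cells (Homo sapiens) for cytotoxicity, read by WST assay, with a stated time of 72 h (a lower number here means a stronger inhibitor, a higher number a weaker inhibitor), the two compounds with a number lie well apart. Compound 1 `COc1cc2c(Nc3nc4ccc(C(=O)Nc5c(C)cc(C)cc5C)cc4s3)ncnc2cc1OCCCN1CCC(C)CC1` gives 6900 nM. Compound 3 `COc1cc2c(Nc3nc4ccc(C(=O)Nc5c(C)cccc5Cl)cc4s3)ncnc2cc1OCCCN1CCCC1` gives 63800 nM, the highest of the two numbers shown, with compound 1 the nearest at a considerably lower number; these two differ in two places, so their gap cannot be pinned to one change. Compound 2 `COc1cc2c(Nc3nc4ccc(C(=O)Nc5c(C)cccc5C)cc4s3)ncnc2cc1OCCCN1CCCC1` returns only a limit of this assay, > 100000 nM, and sits at the limit of > 100000 nM in this assay, at which 1 of the 3 values shown sits. Within the data shown here, the one single-point step that was measured, an at least 1.5-fold lower number from compound 2 to compound 3 (0.19 log units; that floor lies within the scatter), came from replacing a methyl with a chloro on the aromatic ring bound to the amide nitrogen.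

Compound 4 `COc1cc2c(Nc3nc4ccc(C(=O)Nc5c(C)cc(C)cc5C)cc4s3)ncnc2cc1OCCCN1CCCC1` is the next compound in this series. The change from compound 3 is 2,4,6-trimethylphenyl in place of 2-chloro-6-methylphenyl on an amide-type nitrogen. Among the measured compounds shown here, it undoes the chloro-for-methyl step and adds a further methyl, which no measured pair isolates. Reversing the small step from compound 2 to compound 3 points to a somewhat higher number, while the same 2,4,6-trimethylphenyl sits on compound 1, whose number is far lower, though with a different amine. Weighing these, compound 4 is expected to move by a 2.1-fold lower number from compound 3 to compound 4 (0.33 log units; beyond the scatter) and to give about 30000 nM, estimated between 6000 nM and 100000 nM.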

Compound 4, half-maximal inhibitory concentration: 5800 nM
Beside the measured number, compound 4's estimate is 5.2-fold (0.71 log units) above it, outside the stated range (below it).
By their numbers in this assay, from the lowest: compounds 4 and 1 (each within the scatter of the next); then compound 3. At a limit, above all of these: compound 2.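

In this assay, the aromatic ring on the amide-type nitrogen now proves able to shift the result strongly: the change to 2,4,6-trimethylphenyl gives an 11-fold lower number from compound 3 to compound 4 (1.04 log units; beyond the scatter), and adding a single methyl on an aromatic carbon gives an at least 17-fold lower number from compound 2 to compound 4 (1.23 log units; beyond the scatter), whereas the earlier chloro-for-methyl swap gave only an at least 1.5-fold lower number from compound 2 to compound 3 (0.19 log units; that floor lies within the scatter). The step from compound 2 gives only a floor, as compound 2 carries a limit and not a number: the limit of > 100000 nM in this assay, at which 1 of the 4 values shown sits. With 2,4,6-trimethylphenyl held constant, the two amines at the end of the chain cannot be told apart, since exchanging 4-methylpiperidin-1-yl and pyrrolidin-1-yl gives a 1.2-fold lower number from compound 1 to compound 4 (0.08 log units; within the scatter).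

From the compounds shown here alone, the step from compound 3 changes a chloro and adds a methyl together, so the share of each stays open, and a 2-chloro-4,6-dimethylphenyl group on the same amide would separate them. Going by these compounds, it also stays open whether a different amine at the chain end, such as morpholin-4-yl, or a larger group in place of the added methyl, such as ethyl, would keep or move the number in this assay.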